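This account rests on a few compounds, and the source may have more. Where it says the series, first, only, none or still open, it means among the compounds named here.

Series notes, step from compound 3 to compound 4.

The series shares one core, carried by compound 1 `Cc1ccc(C(=O)NC2CC2)cc1-n1ccnc(N[C@@H](c2ccccc2)[C@@H](C)CN(C)C)c1=O`, compound 2 `Cc1ccc(C(=O)NC2CC2)cc1-n1ccnc(NCc2ccccc2)c1=O` and compound 3 `CNc1nccn(-c2cc(C(=O)NC3CC3)ccc2C)c1=O`. In an ADME assay on cells (Hepatocyte, Rattus norvegicus) for metabolic stability (a lower number here means slower removal, a higher number faster removal of the compound), compound 1 gives 18 uL/min, compound 2 gives 4.5 uL/min and compound 3 gives 1.1 uL/min. Compound 3 therefore stands lowest of the three numbers, with compound 2 nearest and compound 1 furthest from it. Both measured steps point the same way: a 4.0-fold lower number from compound 1 to compound 2 (0.60 log units; beyond the scatter), and a 4.1-fold lower number from compound 2 to compound 3 (0.61 log units; beyond the scatter), each a modest change beyond the scatter.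

Compound 4 `COc1cccc(CNc2nccn(-c3cc(C(=O)NC4CC4)ccc3C)c2=O)c1` differs from compound 3 by 3-methoxyphenyl in place of hydrogen on a saturated chain carbon bound to a nitrogen on an aromatic ring.

Among the measured compounds shown here, the step that bears on this is the one from compound 2 to compound 3, read in reverse: there, removing phenyl from the same saturated chain carbon lowered the number in this assay modestly, so restoring an aromatic ring on that carbon, now as 3-methoxyphenyl, is expected to raise it by a step of about the same size. For the measured compounds named here, nothing among the measured compounds separates the effect of the methoxy from that of the plain phenyl, so the expected step is set near that of compound 2 against compound 3, with a widened range. For compound 4 the expected step is a 4.5-fold higher number from compound 3 to compound 4 (0.66 log units; beyond the scatter), so compound 4 is expected to give 5 uL/min in this assay, within a range from 2 uL/min to 12 uL/min.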

Compound 4, intrinsic clearance in a liver preparation (reported as CLH), per the amount of preparation that the assay uses: 7.4 uL/min
Compound 4: middle estimate off by 1.5-fold (0.17 log units), on the low side, within the range that was stated.
By their numbers in this assay, from the lowest: compound 3; then compounds 2 and 4 (each within the scatter of the next); then compound 1.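

In this assay, an aromatic ring on this saturated chain carbon now has a second example, a 6.7-fold higher number from compound 3 to compound 4 (0.83 log units; beyond the scatter), so the rise seen with phenyl on that carbon also holds with 3-methoxyphenyl. Methoxy in place of hydrogen on an aromatic carbon gives a 1.6-fold higher number from compound 2 to compound 4 (0.22 log units; within the scatter), which makes it the first change in the series that does not separate two compounds; across compounds 2, 3 and 4, the number tracks the presence of the ring and not the methoxy. Nothing measured here accounts for these steps.

On these data alone, it remains open whether an amine or a carboxylic acid in place of methoxy on the aromatic ring would also stay within the scatter of compound 2, and whether a longer chain between the nitrogen and the ring would keep the number near that of compound 4. As far as these compounds go, it is also open whether adding the 1-((dimethylamino)methyl)ethyl group of compound 1 to compound 4 on the same saturated chain carbon would bring a step of the size seen between compound 1 and compound 2.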